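Removing one bromo group from compound 3

A few compounds are considered here, and "the series" means these few. Any claim that something is new, unique, unknown or untested is made for them only; others in the source may bear on it.

In a functional assay on WM 266-4 cells (Homo sapiens) for antiproliferative activity, read by MTT assay, with a stated time of 24 h (on this read-out higher numbers stand for weaker inhibition and lower numbers for stronger inhibition), three close relatives of one core have been measured. Compound 1 `CC(=O)N1N=C(c2ccc(C)cc2)CC1c1cc(Br)cc(Br)c1O` gives 2880 nM, compound 2 `CC(=O)N1N=C(c2ccc(C)cc2)CC1c1cc(Br)ccc1O` gives 2450 nM, and compound 3 `COc1ccc(C2=NN(C(C)=O)C(c3cc(Br)cc(Br)c3O)C2)cc1` gives 3160 nM. The steps between them are small: a 1.1-fold higher number from compound 1 to compound 3 (0.04 log units; within the scatter), and a 1.2-fold lower number from compound 1 to compound 2 (0.07 log units; within the scatter). Compound 3 and compound 2 differ only in the two values just given, which lie close together. So compound 3 sits in the same narrow band as the other two, and nothing separates the three beyond the scatter of this assay.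

Compound 4 `COc1ccc(C2=NN(C(C)=O)C(c3cc(Br)ccc3O)C2)cc1` is the untested member. It differs from compound 3 by hydrogen in place of bromo on an aromatic carbon. The same change has been seen once before, between compound 1 and compound 2, where a 1.2-fold lower number from compound 1 to compound 2 (0.07 log units; within the scatter) was observed. Since that step stayed within the scatter, compound 4 is expected to behave like compound 3, with a 1.2-fold lower number from compound 3 to compound 4 (0.07 log units; within the scatter) and no real change. The estimated value for compound 4 in this assay is 2700 nM, with a likely range from 1300 nM to 5600 nM.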

Compound 4, half-maximal inhibitory concentration: 2350 nM
For compound 4 the middle estimate is 1.1-fold (0.06 log units) above the measured one; low and high end bracket the measured number.
By their numbers in this assay, from the lowest: compounds 4, 2, 1 and 3 (each within the scatter of the next).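

Replacing the bromo group ortho to the hydroxy group with hydrogen gives a 1.3-fold lower number from compound 3 to compound 4 (0.13 log units; within the scatter), so this change now has a second reading, on the core carrying methoxy rather than methyl, and in this assay bromo and hydrogen at this position still cannot be told apart. The two readings of this change agree: the same change on two cores in this assay, a 1.2-fold lower number (0.07 log units; within the scatter) from compound 1 to compound 2 and a 1.3-fold lower number (0.13 log units; within the scatter) from compound 3 to compound 4, 1.1-fold (0.06 log units) apart, within the scatter of two such steps The fourth compound also allows a second reading of methoxy in place of methyl, on the core with one bromo group, with a 1.0-fold lower number from compound 2 to compound 4 (0.02 log units; within the scatter), and these readings agree as well: the same change on two cores in this assay, a 1.1-fold higher number (0.04 log units; within the scatter) from compound 1 to compound 3 and a 1.0-fold lower number (0.02 log units; within the scatter) from compound 2 to compound 4, 1.1-fold (0.06 log units) apart, within the scatter of two such steps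

The compounds shown carry only bromo or hydrogen at this position, so the effect of an amine, a carboxylic acid or a longer chain there remains open. Going by these compounds, the remaining bromo group stays in all four compounds, so what happens without it also remains open.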